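Positional isomer of a chloroacetamide-bearing pyrazole ester

The compounds below may be only part of what the source reports. "The series", "measured", "known", "first", "only" and "open" are said of these compounds alone.

Measured compounds:
compound 1 `CCOC(=O)c1cc(-c2ccc(Oc3ccccc3)cc2)nn1Cc1cccc(NC(=O)CCl)c1` — 400 nM
compound 2 `O=C(CCl)Nc1cccc(Cn2nc(-c3ccc(Oc4ccccc4)cc3)cc2C(=O)O)c1` — 9100 nM

In a functional assay on Z-138 cells (Homo sapiens) for inhibition, read by luminescence and CellTiter-Glo, with a stated time of 72 h (on this read-out higher numbers stand for weaker inhibition and lower numbers for stronger inhibition), compound 1 gives 400 nM and is the lowest of the two numbers shown. Within the data shown here, its nearest neighbour is compound 2, which in this assay gives 9100 nM; the only step between them, a 23-fold higher number from compound 1 to compound 2 (1.36 log units; beyond the scatter), is hydrogen in place of ethyl on an oxygen next to a carbonyl group and lies beyond the scatter.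

Compound 3 `CCOC(=O)c1cc(-c2ccc(Oc3ccccc3)cc2)nn1Cc1ccc(NC(=O)CCl)cc1` keeps the ethyl ester of compound 1 and differs from it only in the change (4-(((chloromethyl)carbonyl)amino)phenyl in place of 3-(((chloromethyl)carbonyl)amino)phenyl on a saturated chain carbon bound to an aromatic nitrogen). No measured step touches this change: the single step shown, a 23-fold higher number from compound 1 to compound 2 (1.36 log units; beyond the scatter), alters the ester and not the placement of the amide on the benzyl ring, so it gives no direct guide. The two compounds have the same atoms, joined differently, and the size and direction of the step in this assay cannot be read from the data. Compound 3 is therefore expected to lie near compound 1, with a wide range, giving a step of a 1.8-fold higher number from compound 1 to compound 3 (0.24 log units; within the scatter) that may fall inside or beyond the scatter. The estimate for compound 3 in this assay is 700 nM, between 150 nM and 4000 nM.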

Compound 3, half-maximal inhibitory concentration: 400 nM
Compound 3: middle estimate off by 1.8-fold (0.24 log units), on the high side, within the range that was stated.
By their numbers in this assay, from the lowest: compounds 1 and 3 (each within the scatter of the next); then compound 2.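

In this assay, 4-(((chloromethyl)carbonyl)amino)phenyl in place of 3-(((chloromethyl)carbonyl)amino)phenyl on a saturated chain carbon bound to an aromatic nitrogen gives no change at the digits printed from compound 1 to compound 3 (within the scatter). Among these compounds, with the ethyl ester kept, this read-out therefore does not separate the two placements of the amide on the benzyl ring, a point the earlier compounds could not address. The only other step, a 23-fold higher number from compound 1 to compound 2 (1.36 log units; beyond the scatter), lies at the ester and is beyond the scatter, so among the compounds shown the ester change registers in this assay and the isomer change does not. Nothing available explains why the two isomers match.

The compounds shown leave open whether the two placements would also match if the carboxylic acid of compound 2 replaced the ethyl ester, and whether a primary amide or a longer alkyl chain on the ester oxygen would hold the value of compound 1. They also leave open how much of the value depends on the chloroacetamide itself, which an acrylamide or a plain acetamide at either placement would test.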